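The source may report more compounds than this note shows. Statements on the series, on what has been measured and on what is new or still open speak of the compounds shown alone.

Working notes on the series. In a functional assay on HL-60 cells (Homo sapiens) for inhibition, read by CCK-8 assay, with a stated time of 48 h, tested at 20 uM (on this read-out higher numbers stand for more inhibition of growth at the one concentration tested and lower numbers for less inhibition of growth), compound 1 (`COc1ccc(Cc2nnc(NC(=O)/C(C#N)=C/c3ccccc3OS(=O)(=O)c3ccc(C)cc3)s2)cc1`) gives 25%. In this assay, for the measured compounds named here, compound 2 (`COc1ccc(Cc2nnc(NC(=O)/C(C#N)=C/c3ccccc3OS(=O)(=O)c3ccc(Cl)cc3)s2)cc1`) gives 20%, which places compound 2 within the scatter of compound 1, the only other measured member. Compound 3 (`COc1ccc(Cc2nnc(NC(=O)/C(C#N)=C/c3ccccc3OS(=O)(=O)c3ccc(F)cc3)s2)cc1`) has not yet been measured. It differs from compound 2 by fluoro in place of chloro on an aromatic carbon, para to a large group: fluoro in place of chloro on an aromatic carbon.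

Going by the values given here, one measured step bears on this change, chloro in place of methyl on an aromatic carbon: a number 5 percentage points lower from compound 1 to compound 2 (within the scatter). That step is small and lies within the scatter. Among the compounds with values here, no measured compound carries fluoro, so the comparison remains indirect. With this single step as the guide, no change beyond the scatter is expected in this assay, and no direction can be firmly assigned. The estimated step is a number 2 percentage points higher from compound 2 to compound 3 (within the scatter), which is expected to stay within the scatter. For compound 3 the estimated value is 22%, with an expected range from 10% to 35%.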

Compound 3, percent growth inhibition at one concentration: 25%
The estimate for compound 3 lay 3 percentage points below the measured number; the measured number falls inside the stated range.
By their numbers in this assay, from the lowest: compounds 2, 1 and 3 (each within the scatter of the next).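

In this assay fluoro in place of chloro on the aromatic carbon, para to a large group, gives a number 5 percentage points higher from compound 2 to compound 3 (within the scatter), and fluoro in place of methyl at the same place gives no change at the digits printed from compound 1 to compound 3 (within the scatter). This position has now carried three different small substituents, where the earlier pair offered only methyl and chloro, and all three compounds lie within the scatter of one another, so swapping among these three groups shows no measurable effect on growth inhibition at the one concentration tested. Nothing available on these compounds offers an explanation for how closely the three numbers agree.

The compounds shown leave open whether a group of another kind at this position, such as an amine, a carboxylic acid or a longer alkyl chain, would move the number beyond the scatter. They also leave open whether the same agreement among methyl, chloro and fluoro would hold at other concentrations, and whether a change elsewhere on the shared core would matter more than any change at this position.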